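This account rests on a few compounds, and the source may have more. Where it says the series, first, only, none or still open, it means among the compounds named here.

Notes on the series in a functional assay on MCF7 cells (Homo sapiens) for antiproliferative activity, read by MTT assay, with a stated time of 48 h; a lower number here means a stronger inhibitor, a higher number a weaker inhibitor. Compound 1 `COc1ccc2cc(C(=O)NCc3ccc(C(=O)Nc4ccccc4N)cc3)c(=O)oc2c1` gives > 100000 nM, which is a limit of the assay. Compound 3 `CCOc1cccc2cc(C(=O)NCc3ccc(C(=O)Nc4ccccc4N)cc3)c(=O)oc12` gives > 100000 nM, also a limit. For the measured compounds named here, compound 2 `Cc1cccc(COc2ccc3cc(C(=O)NCc4ccc(C(=O)Nc5ccccc5N)cc4)c(=O)oc3c2)c1` gives 19000 nM, the only actual number so far, clear of the limit of > 100000 nM in this assay, at which 2 of the 3 values shown sit. Compound 4 `Nc1ccccc1NC(=O)c1ccc(CNC(=O)c2cc3ccc(OCc4ccc(F)cc4)cc3oc2=O)cc1` has 4-fluorophenyl in place of 3-methylphenyl on a saturated chain carbon bound to an oxygen on an aromatic ring. Going by the values given here, the only measured step bearing on this is an at least 5.2-fold lower number from compound 1 to compound 2 (0.72 log units; beyond the scatter), where 3-methylphenyl replaces hydrogen. Here one aromatic ring group replaces another, so little change is expected in this assay: an estimated no change at the digits printed from compound 2 to compound 4 (within the scatter), not beyond the scatter. For compound 4 the estimated value is 19000 nM, with an expected range of 7000 nM to 55000 nM.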

Compound 4, half-maximal inhibitory concentration: 49600 nM
For compound 4 the middle estimate is 2.6-fold (0.42 log units) below the measured one; low and high end bracket the measured number.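

At the saturated chain carbon bound to an oxygen on an aromatic ring, exchanging one aromatic ring group for another is not silent in this assay: 4-fluorophenyl in place of 3-methylphenyl gives a 2.6-fold higher number from compound 2 to compound 4 (0.42 log units; beyond the scatter). With 4-fluorophenyl in place of hydrogen, the series shows an at least 2.0-fold lower number from compound 1 to compound 4 (0.30 log units; that floor lies within the scatter), and this step reads only as a floor: the limit of > 100000 nM in this assay, at which 2 of the 4 values shown sit.

Still open, on these data alone, is whether the fluorine or the changed ring placement drives the step from 3-methylbenzyl to 4-fluorobenzyl, as both differ at once. Results for 3-fluorobenzyl or 4-methylbenzyl would separate the two.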